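Swapping a Sulfur Linker for a Phenylpiperazine

A few compounds are considered here, and "the series" means these few. Any claim that something is new, unique, unknown or untested is made for them only; others in the source may bear on it.

Measured so far:
- compound 1 `Cn1c(-c2ccc(NC(=O)CSc3nc4ccccc4o3)cc2)nc(-c2ccccc2)c1-c1ccccc1`, which in a functional assay on MCF7 cells (Homo sapiens) for cytotoxicity, read by MTT assay, with a stated time of 24 h, tested at 0.64 ug/mL (a higher number here means a stronger effect of the compound at the concentration tested, a lower number a weaker effect), gives 18.7%
- compound 2 `Cn1c(-c2ccc(NC(=O)CSc3nc4ccccc4s3)cc2)nc(-c2ccccc2)c1-c1ccccc1`, which gives 0.9%
- compound 3 `CCN1CCN(CC(=O)Nc2ccc(-c3nc(-c4ccccc4)c(-c4ccccc4)n3C)cc2)CC1`, which gives 4.7%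

Among these three, compound 1 stands highest, with compound 3 nearest and compound 2 furthest. The unmeasured compound 4 `Cn1c(-c2ccc(NC(=O)CN3CCN(c4ccccc4)CC3)cc2)nc(-c2ccccc2)c1-c1ccccc1` shares the core of compound 1 and differs from it in one place: 4-phenylpiperazin-1-yl in place of (1,3-benzoxazol-2-yl)sulfanyl on a saturated chain carbon bound to a carbonyl carbon.

For the measured compounds named here, two measured steps bear on this. The closest is a number 14 percentage points lower from compound 1 to compound 3 (beyond the scatter), in which a piperazine also replaced the sulfur-linked group on the same chain carbon. The step of a number 17.8 percentage points lower from compound 1 to compound 2 (beyond the scatter) shows that even a small change in that sulfur-linked group lowered the read-out. Both point the same way, so a drop of roughly the size seen with compound 3 is expected for compound 4, as a number 12.7 percentage points lower from compound 1 to compound 4 (beyond the scatter). Compound 4 is therefore estimated at 6%, within a range of 0% to 18%.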

Compound 4, a percentage reported as activity, at one concentration (the size of the read-out at that concentration, not a potency): 12.1%
Beside the measured number, compound 4's estimate is 6.1 percentage points below it; the measured number falls inside the stated range.
By their numbers in this assay, from the lowest: compounds 2, 3, 4 and 1 (each within the scatter of the next, the first and the last beyond it).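

The step of a number 6.6 percentage points lower from compound 1 to compound 4 (within the scatter) shows that, on this saturated chain carbon bound to a carbonyl carbon, a piperazine need not separate clearly from compound 1, since 4-phenylpiperazin-1-yl stays within the scatter where the 4-ethylpiperazin-1-yl of compound 3 did not. Yet the group on the ring amine nitrogen cannot be ranked, given the step of a number 7.4 percentage points higher from compound 3 to compound 4 (within the scatter) for phenyl in place of ethyl. The one clear separation added is the step of a number 11.2 percentage points higher from compound 2 to compound 4 (beyond the scatter) from the (1,3-benzothiazol-2-yl)sulfanyl compound.

From the compounds shown here alone, whether a benzyl or acetyl group on the piperazine, or a morpholine ring in its place, would stay level with compound 1 remains open. Nothing shown accounts for these differences.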